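Heterobicycle swap at the urea nitrogen in the piperazine series

The source may report more compounds than this note shows. Statements on the series, on what has been measured and on what is new or still open speak of the compounds shown alone.

Compound 3 `O=C(Nc1noc2ccncc12)N1CCN(Cc2cccc(Oc3ccc(Cl)cc3)c2)CC1` gives 2200 nM in an assay on isolated protein for inhibition of Fatty-acid amide hydrolase 1 (Rattus norvegicus), with a stated time of 60 min; on this read-out higher numbers stand for weaker inhibition and lower numbers for stronger inhibition. This is the highest number of the three measured; compound 1 `Cc1nc2cc(NC(=O)N3CCN(Cc4cccc(Oc5ccc(Cl)cc5)c4)CC3)ccc2o1` gives 200 nM and compound 2 `O=C(Nc1noc2ccccc12)N1CCN(Cc2cccc(Oc3ccc(Cl)cc3)c2)CC1` gives 8.1 nM in this assay, so compound 3 is the weakest inhibitor on these numbers.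

The step to compound 4 `O=C(Nc1cn2ccccc2n1)N1CCN(Cc2cccc(Oc3ccc(Cl)cc3)c2)CC1` is a group of 9 heavy atoms (7 carbon, 2 nitrogen; one five-membered aromatic ring with 2 hetero atoms, one six-membered aromatic ring with 1 hetero atom) in place of a group of 9 heavy atoms (6 carbon, 2 nitrogen, 1 oxygen; one five-membered aromatic ring with 2 hetero atoms, one six-membered aromatic ring with 1 hetero atom), on an amide-type nitrogen. All three measured steps change the same fused aromatic group on the amide-type nitrogen and bear on it: a 25-fold lower number from compound 1 to compound 2 (1.39 log units; beyond the scatter), an 11-fold higher number from compound 1 to compound 3 (1.04 log units; beyond the scatter) and a 270-fold higher number from compound 2 to compound 3 (2.43 log units; beyond the scatter). Changes of this group thus move this assay by large amounts in either direction, and no step has been within the scatter.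

Compound 3 stands at the high end, so a move toward lower numbers is the more likely outcome, and compound 4 is expected to reach 300 nM with a range of 40 nM to 2500 nM. This amounts to an expected 7.3-fold lower number from compound 3 to compound 4 (0.87 log units; beyond the scatter), though the measured steps show the size cannot be pinned down closely.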

Compound 4, half-maximal inhibitory concentration: > 10000 nM
Compound 4: no number, only a limit; the forecaster's own chance of this, stated with the estimate: 5%; middle value at least 33-fold (1.52 log units) from the limit.
By their numbers in this assay, from the lowest: compound 2; then compound 1; then compound 3. At a limit, above all of these: compound 4.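

In this assay compound 4 gives no number, only a limit of the assay: the limit of > 10000 nM in this assay, at which 1 of the 4 values shown sits. Even against the weakest measured compound the change still counts, an at least 4.5-fold higher number from compound 3 to compound 4 (0.65 log units; beyond the scatter), and the gaps to the others are wider, an at least 1200-fold higher number from compound 2 to compound 4 (3.09 log units; beyond the scatter) and an at least 50-fold higher number from compound 1 to compound 4 (1.69 log units; beyond the scatter). The earlier groups all carry one oxygen and all gave a measurable number, whereas the group of 7 carbon and 2 nitrogen atoms, the only one without oxygen, leaves inhibition out of range at this amide-type nitrogen, so keeping the ring sizes and the heavy-atom count of compound 3 does not preserve activity.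

Going by these compounds, the true size of these steps stays unknown, and compound 4 alone cannot separate the loss of oxygen from the new placement of nitrogen. On these data alone, how a single phenyl or pyridine ring would stand on this nitrogen also remains open.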